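Phenyl to isopropyl in the amino ester series

A few compounds are considered here, and "the series" means these few. Any claim that something is new, unique, unknown or untested is made for them only; others in the source may bear on it.

Values in a functional assay on HCT-116 cells (Homo sapiens) for inhibition, read by fluorescence, with a stated time of 48 h (on this read-out higher numbers stand for weaker inhibition of growth and lower numbers for stronger inhibition of growth), so far:
- compound 1 `N[C@H](C(=O)OCCCOC1(c2ccc(Cl)cc2)c2ccccc2C(=O)N1Cc1ccccc1)c1ccccc1` gives 14000 nM
- compound 2 `N[C@H](C(=O)OCCCOC1(c2ccc(Cl)cc2)c2ccccc2C(=O)N1Cc1ccc(Cl)cc1)c1ccccc1` gives 12000 nM
- compound 3 `CC(C)[C@H](N)C(=O)OCC(C)(C)COC1(c2ccc(Cl)cc2)c2ccccc2C(=O)N1Cc1ccc(Cl)cc1` gives 11000 nM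

In this assay compound 1 stands level with compounds 2 and 3, all three values lying within the scatter of one another. Compound 4 `CC(C)[C@H](N)C(=O)OCCCOC1(c2ccc(Cl)cc2)c2ccccc2C(=O)N1Cc1ccccc1` is reached through (isopropyl in place of phenyl on a saturated chain carbon bound to an amine nitrogen and a carbonyl carbon), with isopropyl in place of phenyl on a saturated chain carbon bound to an amine nitrogen and a carbonyl carbon. Among the compounds with values here, the only measured step, a 1.2-fold lower number from compound 1 to compound 2 (0.07 log units; within the scatter), is chloro in place of hydrogen on an aromatic carbon, so it does not cover this change. Compound 3 also carries 1-amino-2-methylpropyl and gives 11000 nM, so no change beyond the scatter is expected. The expected step is a 1.2-fold lower number from compound 1 to compound 4 (0.07 log units; within the scatter). For compound 4 the estimated value is 12000 nM, with an expected range from 6500 nM to 22000 nM.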

Compound 4, concentration for 50% growth inhibition: 20000 nM
Estimate against measurement, compound 4: 1.7-fold (0.22 log units) below, within the range that was stated.
By their numbers in this assay, from the lowest: compounds 3, 2, 1 and 4 (each within the scatter of the next).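

In this assay, within the data shown here, isopropyl in place of phenyl on a saturated chain carbon bound to an amine nitrogen and a carbonyl carbon gives a 1.4-fold higher number from compound 1 to compound 4 (0.15 log units; within the scatter), the first reading at this position with the core otherwise unchanged. Removing the aromatic ring here, and going from six heavy atoms to three, therefore leaves the value within the scatter. Nothing available explains this result.

Going by these compounds, whether a carboxylic acid or a longer chain on this carbon would move the value beyond the scatter remains open.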